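This account rests on a few compounds, and the source may have more. Where it says the series, first, only, none or still open, it means among the compounds named here.

Series around the shared core of compound 1 `COc1cc(-c2nn(-c3cccc(NC(=O)Nc4cccc(C(F)(F)F)c4)c3)cc2-c2ccncc2)ccc1Cl`; in a functional assay on NCI-H23 cells (Homo sapiens) for inhibition, read by sulforhodamine B assay, with a stated time of 48 h (on this read-out higher numbers stand for weaker inhibition of growth and lower numbers for stronger inhibition of growth), compound 1 gives 1180 nM. Compound 2 `COc1cc(-c2nn(-c3cccc(NC(=O)Nc4ccc(Cl)c(C(F)(F)F)c4)c3)cc2-c2ccncc2)ccc1Cl` gives 1310 nM in this assay; its number is the larger of the two shown, but the only measured step, a 1.1-fold higher number from compound 1 to compound 2 (0.05 log units; within the scatter), sits within the scatter. Compound 3 `COc1cc(-c2nn(-c3cccc(NC(=O)Nc4ccc(Cl)c(Cl)c4)c3)cc2-c2ccncc2)ccc1Cl` is not yet measured and differs from compound 2 by chloro in place of trifluoromethyl on an aromatic carbon. Going by the values given here, no measured step exchanges a trifluoromethyl group, and the one step on hand stayed within the scatter, so no step beyond the scatter is expected in this assay, with the estimate a 1.1-fold higher number from compound 2 to compound 3 (0.06 log units; within the scatter). Compound 3 is therefore expected at 1500 nM, between 600 nM and 3800 nM.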

Compound 3, concentration for 50% growth inhibition: 1410 nM
Estimate against measurement, compound 3: 1.1-fold (0.03 log units) above; the range from low to high includes it.
By their numbers in this assay, from the lowest: compounds 1, 2 and 3 (each within the scatter of the next).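

In this assay chloro in place of trifluoromethyl, on an aromatic carbon ortho to a chloro group, gives a 1.1-fold higher number from compound 2 to compound 3 (0.03 log units; within the scatter) and so leaves the number within the scatter, although 4 heavy atoms give way to 1. The 3,4-dichlorophenyl group in place of 3-(trifluoromethyl)phenyl gives a 1.2-fold higher number from compound 1 to compound 3 (0.08 log units; within the scatter) and also stays within the scatter, so all three compounds remain indistinguishable. Nothing on hand accounts for this flat result.

Going by these compounds, whether an amine or a carboxylic acid at this position would move the number beyond the scatter remains open. Also open, on these data alone, is how changes elsewhere on the shared core would read.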